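Chain extension at the aromatic carbon of the shared core

A few compounds are considered here, and "the series" means these few. Any claim that something is new, unique, unknown or untested is made for them only; others in the source may bear on it.

Measured compounds:
compound 1 `CCCCCNc1nc(N)c2nc(O)n(Cc3ccccc3)c2n1` — 0.3 mg/kg
compound 2 `CCc1nc(N)c2nc(O)n(Cc3ccccc3)c2n1` — 3 mg/kg
compound 3 `CCCCCSc1nc(N)c2nc(O)n(Cc3ccccc3)c2n1` — 1 mg/kg

The three compounds were tested in a functional assay on the whole organism for activation, with Mus musculus as the target; on this read-out lower numbers stand for an effect already at smaller amounts and higher numbers for an effect only at larger amounts of compound. Compound 2 stands highest of the three numbers with 3 mg/kg; the nearest is compound 3, reached by a 3.0-fold lower number from compound 2 to compound 3 (0.48 log units; beyond the scatter), and the furthest is compound 1, since a 10-fold higher number from compound 1 to compound 2 (1.00 log units; beyond the scatter).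

Compound 4 `CCCCc1nc(N)c2nc(O)n(Cc3ccccc3)c2n1` differs from compound 2 as follows: ethyl in place of hydrogen on a saturated chain carbon, two bonds along the chain from an aromatic carbon. The same difference, cut one bond further out, reads ethyl to butyl.

For the measured compounds named here, two measured steps bear on this change, though each alters the linking atom as well as the chain: a 3.0-fold lower number from compound 2 to compound 3 (0.48 log units; beyond the scatter) and a 10-fold higher number from compound 1 to compound 2 (1.00 log units; beyond the scatter). Both show that the longer chains on the aromatic carbon come with lower numbers than the ethyl of compound 2. Going by the values given here, no step here lengthens a plain carbon chain alone, so the size is uncertain. A lower number is therefore expected for compound 4 in this assay, the step from compound 2 being estimated at a 3.0-fold lower number from compound 2 to compound 4 (0.48 log units; beyond the scatter). Compound 4 is expected to give 1 mg/kg, with a range from 0.3 mg/kg to 3 mg/kg.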

Compound 4, minimum effective dose: 0.3 mg/kg
Compound 4: middle estimate off by 3.3-fold (0.52 log units), on the high side, within the range that was stated.
By their numbers in this assay, from the lowest: compounds 1 and 4 (each within the scatter of the next); then compound 3; then compound 2.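

For the compounds shown here, compound 4 gives the first measurement in which only the carbon chain grows while its attachment to the aromatic carbon stays the same: a 10-fold lower number from compound 2 to compound 4 (1.00 log units; beyond the scatter) in this assay, so chain length alone moves this read-out. Butyl in place of pentylamino gives no change at the digits printed from compound 1 to compound 4 (within the scatter), and butyl in place of pentylsulfanyl gives a 3.3-fold lower number from compound 3 to compound 4 (0.52 log units; beyond the scatter), which shows that a chain joined directly through carbon can match the number of the pentylamino compound and differ from that of the pentylsulfanyl compound. The data at hand offer no independent measurement that explains these steps.

On these data alone, it remains open whether a propyl group would already lie close to butyl, and whether a longer chain such as pentyl or hexyl would hold the same number. A branched isobutyl chain or a butoxy group at this position also remains untested by the compounds shown here.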